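The source may report more compounds than this note shows. Statements on the series, on what has been measured and on what is new or still open speak of the compounds shown alone.

Compound 1, `O=C(/C=C\Nc1ccc(F)cc1)c1cn(-c2ccccc2)nc1-c1ccc(Cl)cc1`, gives in an ADME assay on HaCaT cells (Homo sapiens) for antiproliferative activity, read by MTT assay, with a stated time of 48 h (a lower number here means a stronger inhibitor, a higher number a weaker inhibitor), the value > 50000 nM, which is a limit of the assay. Compound 2, `COc1ccc(N/C=C\C(=O)c2cn(-c3ccccc3)nc2-c2ccc(Cl)cc2)cc1`, gives in this assay 30800 nM.

Compound 2 therefore holds the only number shown; the other value is a limit. Compound 3, `COc1ccc(N/C=C\C(=O)c2cn(-c3ccccc3)nc2-c2ccc(OC)cc2)cc1`, differs from compound 2 in one place: methoxy in place of chloro on an aromatic carbon. Going by the values given here, the single measured step, an at least 1.6-fold lower number from compound 1 to compound 2 (0.21 log units; that floor lies within the scatter), concerns methoxy in place of fluoro on an aromatic carbon and lies within the scatter, and the limit of > 50000 nM in this assay, at which 1 of the 2 values shown sits, leaves even its size uncertain. Compound 3 is thus expected to show no step beyond the scatter, a 1.0-fold lower number from compound 2 to compound 3 (0.01 log units; within the scatter). The estimate for compound 3 is 30000 nM, between 10000 nM and 90000 nM.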

Compound 3, half-maximal inhibitory concentration: > 50000 nM
Compound 3: a limit, no number (the forecaster's own chance of this, stated with the estimate: 35%); middle value at least 1.6-fold (0.22 log units) away from the limit.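

The change from 4-chlorophenyl to 4-methoxyphenyl brings, in this assay, an at least 1.6-fold higher number from compound 2 to compound 3 (0.21 log units; that floor lies within the scatter). Going by these compounds alone, this is the first reading at this position, and it gives no sign that methoxy here lowers the number. The true size of the step stays unknown because of where the value of compound 3 sits: the limit of > 50000 nM in this assay, at which 2 of the 3 values shown sit.

What the compounds leave open is whether an amine or a carboxylic acid in place of the chloro would lower the number in this assay beyond the scatter. Whether an unsubstituted phenyl at this place would differ from compound 2 is open too.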